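Cytotoxicity notes on the thioether amide series, compound 4 pending

The source may report more compounds than this note shows. Statements on the series, on what has been measured and on what is new or still open speak of the compounds shown alone.

Measured in an ADME assay on CEM-SS cells (Homo sapiens) for cytotoxicity, read by XTT assay, with a stated time of 6 days; on this read-out higher numbers stand for lower toxicity in this test and lower numbers for higher toxicity in this test:
compound 1, `CCCC(=O)OCSc1ccccc1C(=O)NCCC(N)=O`, gives > 100 uM, which is a limit of the assay and not a number.
compound 2, `CCCC(=O)OCSc1ccccc1C(=O)NCCCCCC(N)=O`, gives 16.3 uM.
compound 3, `CCCC(=O)OCSc1ccccc1C(=O)NCC(=O)OC`, gives 27.3 uM.

Compound 2 and compound 3 sit within the scatter of each other, a 1.7-fold higher number from compound 2 to compound 3 (0.22 log units; within the scatter), so no order between them can be read. Compound 1 alone reaches the limit (the limit of > 100 uM in this assay, at which 1 of the 3 values shown sits). Both steps away from compound 1 move the number down beyond the scatter: an at least 6.1-fold lower number from compound 1 to compound 2 (0.78 log units; beyond the scatter) and an at least 3.6-fold lower number from compound 1 to compound 3 (0.56 log units; beyond the scatter).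

Compound 4, `C#CCNC(=O)CNC(=O)c1ccccc1SCOC(=O)CCC`, is not yet measured. Against compound 2 the change is propargylcarbamoyl in place of 4-carbamoylbutyl on a saturated chain carbon bound to an amide-type nitrogen. Within the data shown here, no measured step carries this exact change; the nearest is an at least 3.6-fold lower number from compound 1 to compound 3 (0.56 log units; beyond the scatter), where a chain-end amide gave way to an ester, and an at least 6.1-fold lower number from compound 1 to compound 2 (0.78 log units; beyond the scatter), where the chain lengthened. Compound 4 keeps an amide end and shortens the chain, so a step of the size a 1.5-fold higher number from compound 2 to compound 4 (0.19 log units; within the scatter) is expected, toward a somewhat higher number, yet likely within the scatter. Compound 4 is estimated at 25 uM, between 10 uM and 70 uM.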

Compound 4, half-maximal toxic concentration: 95.4 uM
The estimate for compound 4 lay 3.8-fold (0.58 log units) below the measured number; measured number above the stated range.
By their numbers in this assay, from the lowest: compounds 2 and 3 (each within the scatter of the next); then compound 4. At a limit, above all of these: compound 1.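

In this assay, among these compounds, propargylcarbamoyl in place of 4-carbamoylbutyl on a saturated chain carbon bound to an amide-type nitrogen gives the first upward steps: a 5.9-fold higher number from compound 2 to compound 4 (0.77 log units; beyond the scatter) and, with propargylamino in place of methoxy on a carbonyl carbon, a 3.5-fold higher number from compound 3 to compound 4 (0.54 log units; beyond the scatter). Among the compounds shown here, until now, the only steps away from compound 1 led down, so a change at this position does not have to lower the number, with compound 2 and compound 3 as the cases that do. The step of an at least 1.0-fold lower number from compound 1 to compound 4 (0.02 log units; that floor lies within the scatter) cannot be read, since compound 1 sits at a limit and not at a number: the limit of > 100 uM in this assay, at which 1 of the 4 values shown sits.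

The compounds shown leave open whether the triple bond carries the rise, which a saturated propyl group on the same amide nitrogen would test. From the compounds shown here alone, how a carboxylic acid at the chain end would read in this assay also stays open.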